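Compound 3 to compound 4: replacing tert-butyl

The compounds below may be only part of what the source reports. "The series", "measured", "known", "first", "only" and "open" are said of these compounds alone.

- compound 1 `O=C(CCc1cccc2c1B(O)OC2)Nc1ccccc1` gives 350 nM in a functional assay on HCT-116 cells (Homo sapiens) for antiproliferative activity, read by MTT assay, with a stated time of 72 h; on this read-out lower numbers stand for stronger inhibition and higher numbers for weaker inhibition
- compound 2 `O=C(CCc1cccc2c1B(O)OC2)Nc1ccc(I)cc1` gives 50000 nM in this assay
- compound 3 `CC(C)(C)c1ccc(NC(=O)CCc2cccc3c2B(O)OC3)cc1` gives 19000 nM in this assay

Compound 3 holds the second highest of the three numbers, nearer to compound 2 than to compound 1. Compound 4 `CC(C)(C)OC(=O)NCc1ccc(NC(=O)CCc2cccc3c2B(O)OC3)cc1` carries ((tert-butoxycarbonyl)amino)methyl in place of tert-butyl on an aromatic carbon, para to a large group, as counted here: ((tert-butoxycarbonyl)amino)methyl in place of tert-butyl on an aromatic carbon.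

Two large steps bear on this place: a 140-fold higher number from compound 1 to compound 2 (2.15 log units; beyond the scatter) and a 54-fold higher number from compound 1 to compound 3 (1.73 log units; beyond the scatter), each replacing hydrogen there. Exchanging one group for the other moved the number far less: a 2.6-fold lower number from compound 2 to compound 3 (0.42 log units; beyond the scatter). Going by the values given here, both substituted compounds therefore stand high, and none of the three goes against this, though no measured compound carries a group like the entering one. No clear step in either direction is expected, so the estimate stays wide. The estimated change is a 1.3-fold lower number from compound 3 to compound 4 (0.10 log units; within the scatter) in this assay. Compound 4 is expected at 15000 nM, with an estimated range from 3000 nM to 60000 nM.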

Compound 4, half-maximal inhibitory concentration: 2300 nM
Beside the measured number, compound 4's estimate is 6.5-fold (0.81 log units) above it; the measured number lies below the stated range.
By their numbers in this assay, from the lowest: compound 1; then compound 4; then compound 3; then compound 2.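

In this assay, substitution at this place no longer reads as uniformly high: an 8.3-fold lower number from compound 3 to compound 4 (0.92 log units; beyond the scatter) and a 22-fold lower number from compound 2 to compound 4 (1.34 log units; beyond the scatter). Heavy-atom count does not order the tert-butyl and ((tert-butoxycarbonyl)amino)methyl compounds, since the entering group has 9 heavy atoms against 4 and still gives the lower number. Hydrogen nevertheless keeps the lowest number of the four, with a 6.6-fold higher number from compound 1 to compound 4 (0.82 log units; beyond the scatter), and no evidence is available to account for the difference between the groups.

Open, going by these compounds, is which part of the entering group goes with the lower number: the carbamate, its tert-butyl end or the methylene link. A free aminomethyl or a hydroxymethyl group on this aromatic carbon would separate these parts, and would also test whether any substituent here can match hydrogen.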